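Fluoro for Hydrogen on the Pendant Phenyl of Compound 2

This account rests on a few compounds, and the source may have more. Where it says the series, first, only, none or still open, it means among the compounds named here.

Measured compounds:
Compound 1, `O=C(Nc1ccc(Oc2ccnc3[nH]ccc23)cc1)c1cc2cccnc2n(-c2ccc(F)cc2)c1=O`, gives 210 nM in a functional assay on A549 cells (Homo sapiens) for antiproliferative activity, read by MTT assay, with a stated time of 72 h; on this read-out higher numbers stand for weaker inhibition and lower numbers for stronger inhibition.
Compound 2, `Cn1ccc2c(Oc3ccc(NC(=O)c4cc5cccnc5n(-c5ccccc5)c4=O)cc3)ccnc21`, gives 850 nM in this assay.

Of the two measured compounds, compound 2 stands with the highest number in this assay. Its nearest neighbour is compound 1, whose number is lower by a margin beyond the usual scatter. Compound 1 and compound 2 differ in more than one place, so the two values only show that the pair sits apart; they do not say which change carries the gap.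

Compound 3, `Cn1ccc2c(Oc3ccc(NC(=O)c4cc5cccnc5n(-c5ccc(F)cc5)c4=O)cc3)ccnc21`, is not yet measured. It differs from compound 2 in a single place: fluoro in place of hydrogen on an aromatic carbon. A lower number than compound 2 is expected for compound 3, because compound 1 with the same 4-fluorophenyl gives 210 nM where compound 2 gives 850 nM. From the compounds shown here alone, the support is weak, since the other difference between those two compounds remains untested on its own. Compound 3 is accordingly expected to come in at 450 nM, within a range from 150 nM to 1400 nM. That expectation means a step of a 1.9-fold lower number from compound 2 to compound 3 (0.28 log units; within the scatter), downward and only marginally beyond the scatter.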

Compound 3, half-maximal inhibitory concentration: 210 nM
Estimate against measurement, compound 3: 2.1-fold (0.33 log units) above; low and high end bracket the measured number.
By their numbers in this assay, from the lowest: compounds 1 and 3 (each within the scatter of the next); then compound 2.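

In this assay, the change from phenyl to 4-fluorophenyl, made in one place, gives a 4.0-fold lower number from compound 2 to compound 3 (0.61 log units; beyond the scatter) and so ties a measurable change in this read-out to fluoro in place of hydrogen on this aromatic carbon, which the earlier pair, differing in more than one place, could not do. The other change, methyl in place of hydrogen on an aromatic nitrogen, gives no change at the digits printed from compound 1 to compound 3 (within the scatter) when the 4-fluorophenyl is present, so with that group in place the methyl makes no difference that this read-out can detect, and the fluoro step alone spans the whole gap seen between the printed values of the two earlier compounds. No measurement among the data shown offers an explanation for the size of the fluoro step.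

The compounds shown leave open how chloro, methoxy or an amine would read at this same place on the pendant ring, since the fluoro step is the only change there. From the compounds shown here alone, it also remains open whether the methyl on the aromatic nitrogen would stay as silent with the plain phenyl present, or whether an ethyl or a longer chain on that nitrogen would do the same.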